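Removing the hydroxyl-bearing ring from compound 2

The source may hold more compounds than are shown below. What is called first, only, known or untested is meant among the compounds shown, and "the series" means these compounds.

Measured so far in a functional assay on ACHN cells (Homo sapiens) for inhibition, read by sulforhodamine B assay, with a stated time of 48 h; on this read-out lower numbers stand for stronger inhibition of growth and higher numbers for weaker inhibition of growth:
Compound 1 `Cc1ccc(C2=NN(c3ccc(S(C)(=O)=O)cc3)C(=O)CC2)cc1` gives 4020 nM
Compound 2 `Cc1cc(O)ccc1C1=NN(c2ccc(S(C)(=O)=O)cc2)C(=O)CC1` gives 37800 nM

Compound 2 has the higher of the two numbers, so it is the weaker growth inhibitor. The next change leads to compound 3 `CCc1ccc(C2=NN(c3ccc(S(C)(=O)=O)cc3)C(=O)CC2)cc1` and puts 4-ethylphenyl in place of 4-hydroxy-2-methylphenyl on a carbon with a double bond to nitrogen. Among the measured compounds shown here, one measured step bears on this: a 9.4-fold higher number from compound 1 to compound 2 (0.97 log units; beyond the scatter), which came with 4-hydroxy-2-methylphenyl replacing 4-methylphenyl. For the measured compounds named here, the change to 4-ethylphenyl removes that group again and leaves a ring much like the one in compound 1 at 4020 nM. A step of similar size towards a lower number is therefore expected in this assay, estimated as a 9.5-fold lower number from compound 2 to compound 3 (0.98 log units; beyond the scatter) and beyond the scatter. The estimated value for compound 3 is 4000 nM within an expected range from 1500 nM to 12000 nM in this read-out.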

Compound 3, concentration for 50% growth inhibition: 8590 nM
Compound 3: the middle estimate sits 2.1-fold (0.33 log units) below what was measured; low and high end bracket the measured number.
By their numbers in this assay, from the lowest: compound 1; then compound 3; then compound 2.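

In this assay, 4-ethylphenyl in place of 4-hydroxy-2-methylphenyl brings a 4.4-fold lower number from compound 2 to compound 3 (0.64 log units; beyond the scatter) and so regains much of the growth inhibition lost in compound 2. Methyl in place of hydrogen on the saturated chain carbon bound to the aromatic ring brings a 2.1-fold higher number from compound 1 to compound 3 (0.33 log units; beyond the scatter) and so weakens inhibition, even though the change is small. This position therefore responds to a slight lengthening of the alkyl group, not only to the hydroxyl-bearing ring. Whether a longer chain such as propyl or a ring-bound amine would raise or lower the number stays open, and nothing measured here gives a reason for either step.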